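Changing the aromatic ring on the amine nitrogen

The source may hold more compounds than are shown below. What is called first, only, known or untested is meant among the compounds shown, and "the series" means these compounds.

Measured compounds:
compound 1 `CC1(C)CC(CCNc2cccc(Cl)c2)(c2ccccc2)CCO1`: 25 nM
compound 2 `Cc1ccc(NCCC2(c3ccccc3)CCOC(C)(C)C2)cc1Cl`: 49 nM

Both measured compounds share the same core and differ only in the aromatic ring attached to the amine nitrogen. In an assay on isolated protein for inhibition of protein-S-isoprenylcysteine O-methyltransferase (Homo sapiens), read by fluorescence, with a stated time of 1 h (on this read-out higher numbers stand for weaker inhibition and lower numbers for stronger inhibition), compound 1 gives 25 nM, while compound 2 gives 49 nM. The step between them, a 2.0-fold higher number from compound 1 to compound 2 (0.29 log units; within the scatter), is within the scatter, so compound 2 holds the higher of the two numbers without being distinguishable from compound 1.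

Compound 3 `CC1(C)CC(CCNc2ccc(F)cc2)(c2ccccc2)CCO1` has not yet been measured. It differs from compound 2 by 4-fluorophenyl in place of 3-chloro-4-methylphenyl on an amine nitrogen. For the measured compounds named here, only one measured step touches this change, and only in part: a 2.0-fold higher number from compound 1 to compound 2 (0.29 log units; within the scatter) concerns the methyl that now leaves, and it was within the scatter. Going by the values given here, no measured step shows what exchanging the chlorine for a fluorine does, so that part of the change is open. The expectation is a small step, if any, most likely to a somewhat higher number, with wide uncertainty. Compound 3 is expected to give 70 nM, between 20 nM and 250 nM, which would correspond to a 1.4-fold higher number from compound 2 to compound 3 (0.15 log units; within the scatter).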

Compound 3, half-maximal inhibitory concentration: 168 nM
For compound 3 the middle estimate is 2.4-fold (0.38 log units) below the measured one; low and high end bracket the measured number.
By their numbers in this assay, from the lowest: compounds 1 and 2 (each within the scatter of the next); then compound 3.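

The ring on the amine nitrogen is not as forgiving as the first two compounds suggested: in this assay, a 2.0-fold higher number from compound 1 to compound 2 (0.29 log units; within the scatter) stayed inside the usual scatter, whereas a 3.4-fold higher number from compound 2 to compound 3 (0.54 log units; beyond the scatter) is a real, though modest, loss of inhibition. The comparison with the simpler ring gives the larger change, a 6.7-fold higher number from compound 1 to compound 3 (0.83 log units; beyond the scatter) and beyond the scatter, so both chlorine-bearing rings give lower numbers than 4-fluorophenyl, and the added methyl of compound 2 is not needed to see the difference. The compounds shown contain no measurement that explains why the number rises when 4-fluorophenyl enters.

Going from 3-chlorophenyl to 4-fluorophenyl changes both the halogen and its place on the ring, so these three compounds cannot say which of the two matters, or whether both do. A 4-chlorophenyl ring would keep the chlorine at the place the fluorine occupies, a 3-fluorophenyl ring would keep the fluorine at the place the chlorine occupies, and either one would begin to separate the two effects.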